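Swapping Cyclopropylcarbonyl for Benzyl: Expected Microsomal Stability

This account rests on a few compounds, and the source may have more. Where it says the series, first, only, none or still open, it means among the compounds named here.

Measured so far:
Compound 1, `CCCCCNc1nc(Nc2ccc([N+](=O)[O-])cc2)nc(OCC(F)(F)F)n1`, in an ADME assay on microsomes from liver (Rattus norvegicus) for metabolic stability, with a stated time of 10 min (on this read-out higher numbers stand for a more stable compound and lower numbers for a less stable compound), gives 35%.
Compound 2, `CC(C)C(=O)NCCS(=O)(=O)NC(=O)c1ccc(Nc2nc(NC3(c4ccc(Cl)cc4)CC3)nc(OCC(F)(F)F)n2)cc1`, in this assay gives 84%.
Compound 3, `O=C(NS(=O)(=O)CCNC(=O)C1CC1)c1ccc(Nc2nc(NC3(c4ccc(Cl)cc4)CC3)nc(OCC(F)(F)F)n2)cc1`, in this assay is recorded as "not active" (no number reported).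

Compound 3 therefore has no single number on this read-out; only a description stands for it, so it cannot be placed against compound 1 or compound 2 on the scale. Compound 4, `O=C(NS(=O)(=O)CCNCc1ccccc1)c1ccc(Nc2nc(NC3(c4ccc(Cl)cc4)CC3)nc(OCC(F)(F)F)n2)cc1`, has not yet been measured. It differs from compound 3 in one place: benzyl in place of cyclopropylcarbonyl on an amine nitrogen. Within the data shown here, no measured pair shows the effect of this kind of change, so the size and direction of the step in this assay are open: a shift beyond the scatter in either direction is possible, and nothing seen so far points one way. Among the measured compounds shown here, the estimate for compound 4 leans on compound 2, whose value 84% is the only number for a compound sharing most of this structure, and on compound 1 giving 35% for a smaller compound with the shared core. Compound 4 is expected to give about 55% in this assay, within a range from 25% to 85%.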

Compound 4, percent of the compound remaining: 100%
Estimate against measurement, compound 4: 45 percentage points below, and the stated range ends below it.
By their numbers in this assay, from the lowest: compound 1; then compound 2; then compound 4.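

On an amine nitrogen, benzyl in place of isopropylcarbonyl gives a number 16 percentage points higher from compound 2 to compound 4 (beyond the scatter) in this assay for this pair of compounds. Among these compounds, this is the first numerical reading of a change at this position, and it shows that a carbonyl on this nitrogen is not needed for a high share of compound to remain: compound 4, which has an amine there and no amide, gives 100% in this test. Nothing available here explains the rise.

From the compounds shown here alone, compound 3 has no number, so the step from cyclopropylcarbonyl to benzyl cannot be read, and the effect of that particular swap stays unknown. Going by these compounds, it also remains open whether the benzyl ring matters or whether a free amine, a simple methyl or a longer phenethyl chain on this nitrogen would read the same.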